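A few compounds are considered here, and "the series" means these few. Any claim that something is new, unique, unknown or untested is made for them only; others in the source may bear on it.

In a functional assay on CCRF-CEM cells (Homo sapiens) for antiproliferative activity, read by MTT assay, with a stated time of 48 h, tested at 100 uM (a lower number here means a stronger effect, a higher number a weaker effect of the compound at the concentration tested), compound 1 `OC(CCn1nc2c(Br)c(Br)c(Br)c(Br)c2n1)c1cccc(Br)c1` gives 0%; compound 2 `OC(CCn1nc2c(Br)c(Br)c(Br)c(Br)c2n1)c1cccc(Cl)c1` gives 0%, and compound 3 `C[C@H](O)CCn1nc2c(Br)c(Br)c(Br)c(Br)c2n1` gives 10%. Compound 1 stands level with compound 2 at the lowest of the three numbers, and compound 3 lies within the scatter of both. The change from compound 1 to compound 2 was no change at the digits printed from compound 1 to compound 2 (within the scatter). Compound 4 `OC(CCn1nc2c(Br)c(Br)c(Br)c(Br)c2n1)c1ccc(Br)cc1` differs from compound 1 by 4-bromophenyl in place of 3-bromophenyl on a saturated chain carbon bound to an oxygen on a saturated carbon and a saturated chain carbon. Going by the values given here, no measured step touches this change, yet every compound here shows little effect, so the expected step of a number 3 percentage points higher from compound 1 to compound 4 (within the scatter) stays within the scatter, with no direction beyond it. For compound 4 the estimate in this assay is 3%, in a range from 0% to 15%.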

Compound 4, a percentage reported as activity, at one concentration (the size of the read-out at that concentration, not a potency): 0%
For compound 4 the middle estimate is 3 percentage points above the measured one; the measured number falls inside the stated range.
By their numbers in this assay, from the lowest: compounds 1, 2, 4 and 3 (each within the scatter of the next).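

In this assay, 4-bromophenyl in place of 3-bromophenyl gives no change at the digits printed from compound 1 to compound 4 (within the scatter) and 4-bromophenyl in place of 3-chlorophenyl gives no change at the digits printed from compound 2 to compound 4 (within the scatter) on the same chain carbon. The earlier step changed only which halogen the phenyl ring carried, whereas these show that moving the bromine around that ring also leaves the number unmoved at this single concentration. Nothing available explains this result. Still open, from the compounds shown here alone, is whether an amine in place of the hydroxyl, or a longer chain, would shift the number.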